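Swapping a Tetrazole for an Acylsulfonamide on a Shared Core

A few compounds are considered here, and "the series" means these few. Any claim that something is new, unique, unknown or untested is made for them only; others in the source may bear on it.

Of the compounds shown here, three built on one core have been measured in a physicochemical assay for solubility, at pH 6; a lower number here means a less soluble compound, a higher number a more soluble compound. Compound 1 `N#Cc1ccc(-c2cc(-c3ccc(C(N)=O)cc3)cc(-c3ccco3)n2)cc1` gives 10000 nM, compound 2 `Cn1nncc1-c1cc(-c2ccc(C(N)=O)cc2)cc(-c2ccc(C#N)cc2)n1` gives 32000 nM, and compound 3 `N#Cc1ccc(-c2cc(-c3ccc(-c4nnn[nH]4)cc3)cc(-c3ccco3)n2)cc1` gives 18000 nM. Compound 3 thus stands between the other two, and the numbers of compounds 2 and 3 do not differ beyond the scatter, nor do those of compounds 1 and 3, as a 1.8-fold higher number from compound 1 to compound 3 (0.26 log units; within the scatter) shows. Within the data shown here, the one step that moves the numbers is a 3.2-fold higher number from compound 1 to compound 2 (0.51 log units; beyond the scatter), at a different position of the core.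

Compound 4 `CS(=O)(=O)NC(=O)c1ccc(-c2cc(-c3ccc(C#N)cc3)nc(-c3ccco3)c2)cc1` differs from compound 3 in one place: (methylsulfonyl)carbamoyl in place of 1H-tetrazol-5-yl on an aromatic carbon. Among the measured compounds shown here, the only measured step at that position, a 1.8-fold higher number from compound 1 to compound 3 (0.26 log units; within the scatter), stayed within the scatter, so the groups tried there have so far left this assay untouched. For the measured compounds named here, no measured step covers the (methylsulfonyl)carbamoyl group itself. The expectation for compound 4 is therefore a step of no change at the digits printed from compound 3 to compound 4 (within the scatter), nothing beyond the scatter in either direction, with an estimated value of 18000 nM and a range from 7000 nM to 45000 nM.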

Compound 4, solubility: 32000 nM
The estimate for compound 4 lay 1.8-fold (0.25 log units) below the measured number, within the range that was stated.
By their numbers in this assay, from the lowest: compounds 1, 3, 2 and 4 (each within the scatter of the next, the first and the last beyond it).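

In this assay, among these compounds, the position carrying the carbamoyl group turns out not to be silent: placing methylsulfonyl on the amide-type nitrogen gives a 3.2-fold higher number from compound 1 to compound 4 (0.51 log units; beyond the scatter) and is the only step at this position that goes beyond the scatter. Replacing 1H-tetrazol-5-yl with (methylsulfonyl)carbamoyl, a group with no ring, gives a 1.8-fold higher number from compound 3 to compound 4 (0.25 log units; within the scatter) and so separates neither group from the other on these numbers. Nothing available explains why the methylsulfonyl step moves the number.

As far as these compounds go, what a carboxylic acid or a longer chain on the sulfonyl group, such as ethylsulfonyl, would give at this position remains open. So does whether the methylsulfonyl step holds on a core carrying 1-methyl-1H-1,2,3-triazol-5-yl in place of furan-2-yl.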